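Compound 3: swapping the amide group

The source may hold more compounds than are shown below. What is called first, only, known or untested is meant among the compounds shown, and "the series" means these compounds.

Measured in an in vivo functional assay on the whole organism for inhibition, with Rattus norvegicus as the target; a lower number here means that less compound is needed, a higher number that more compound is needed for the effect:
Compound 1 `CCCCc1nc(C)c(CC(=O)N2CCC[C@H]2C(=O)OC)c(=O)n1Cc1ccc(-c2ccccc2-c2nnn[nH]2)cc1`: 0.043 mg/kg
Compound 2 `CCCCc1nc(C)c(CCC(=O)N2CCC[C@H]2C(=O)OC)c(=O)n1Cc1ccc(-c2ccccc2-c2nnn[nH]2)cc1`: 0.063 mg/kg

For the measured compounds named here, the two measured compounds cannot be told apart in this assay, as the only measured step is a 1.5-fold higher number from compound 1 to compound 2 (0.17 log units; within the scatter). Compound 2 therefore stands level with compound 1 within the scatter. Compound 3 `CCCCc1nc(C)c(CCC(=O)N2CCOCC2)c(=O)n1Cc1ccc(-c2ccccc2-c2nnn[nH]2)cc1` has not yet been measured, and it differs from compound 2 at the amide: morpholin-4-yl in place of 2-(methoxycarbonyl)pyrrolidin-1-yl on a carbonyl carbon. The measured step keeps the 2-(methoxycarbonyl)pyrrolidin-1-yl group in both compounds, so it bears on this change only indirectly. No measurement shows what replacing that group does. On these data alone, a step beyond the scatter is therefore not expected with any confidence, and the direction remains open, although the estimate leans slightly towards a higher number. The estimate means an expected 1.4-fold higher number from compound 2 to compound 3 (0.15 log units; within the scatter). For compound 3 the estimated value is 0.09 mg/kg, with an expected range of 0.03 mg/kg to 0.3 mg/kg.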

Compound 3, dose for half-maximal effect: 0.143 mg/kg
The estimate for compound 3 lay 1.6-fold (0.20 log units) below the measured number; low and high end bracket the measured number.
By their numbers in this assay, from the lowest: compounds 1 and 2 (each within the scatter of the next); then compound 3.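

In this assay, the group on the carbonyl carbon proves to matter: morpholin-4-yl in place of 2-(methoxycarbonyl)pyrrolidin-1-yl gives a 2.3-fold higher number from compound 2 to compound 3 (0.36 log units; beyond the scatter) and so moves the number beyond the scatter, which the chain change between compound 1 and compound 2 did not do. With the chain change added, ((morpholin-4-yl)carbonyl)methyl in place of (2-(methoxycarbonyl)pyrrolidin-1-yl)carbonyl gives a 3.3-fold higher number from compound 1 to compound 3 (0.52 log units; beyond the scatter) and points the same way, with more compound needed for the effect. Nothing available accounts for this difference between the two groups.

The compounds shown do not separate the methoxycarbonyl group from the ring that carries it, so a plain pyrrolidin-1-yl amide or the corresponding carboxylic acid would be needed to tell the two apart. They also leave open how morpholin-4-yl behaves on the chain of compound 1.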